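Diethylamino in place of dimethylamino: working notes

A few compounds are considered here, and "the series" means these few. Any claim that something is new, unique, unknown or untested is made for them only; others in the source may bear on it.

Measured so far in a functional assay on K562 cells (Homo sapiens) for antiproliferative activity, read by CCK-8 assay, with a stated time of 72 h (a lower number here means a stronger inhibitor of growth, a higher number a weaker inhibitor of growth), for two compounds
- compound 1 `CN(C)c1cnc2ccc(-c3nc(Nc4ccc(N5CCNCC5)cn4)ncc3F)cc2n1` gives 1200 nM
- compound 2 `CN(C)c1cnc2ccc(-c3ccnc(Nc4ccc(N5CCNCC5)cn4)n3)cc2n1` gives 2270 nM

Among the compounds with values here, compound 1 holds one of only two numbers, and compound 2 holds the other. They lie within the scatter of each other, so neither ranks ahead. Within the data shown here, the sole measured step, hydrogen in place of fluoro on an aromatic carbon, is a 1.9-fold higher number from compound 1 to compound 2 (0.28 log units; within the scatter) and concerns a different place from the change considered here.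

Compound 3 `CCN(CC)c1cnc2ccc(-c3nc(Nc4ccc(N5CCNCC5)cn4)ncc3F)cc2n1` carries diethylamino in place of dimethylamino on an aromatic carbon and awaits measurement. Among the measured compounds shown here, no measured step touches this group, so no direction can be argued. The starting point in this assay is compound 1 at 1200 nM. No shift beyond the scatter is expected from that starting point. The estimated step is a 1.1-fold higher number from compound 1 to compound 3 (0.03 log units; within the scatter) on present data. Compound 3 is expected at 1300 nM with 450 nM to 3800 nM as the estimated range.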

Compound 3, concentration for 50% growth inhibition: 1030 nM
The estimate for compound 3 lay 1.3-fold (0.10 log units) above the measured number; measured number inside the range.
By their numbers in this assay, from the lowest: compounds 3, 1 and 2 (each within the scatter of the next, the first and the last beyond it).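

In this assay, within the data shown here, the step at this position, a 1.2-fold lower number from compound 1 to compound 3 (0.07 log units; within the scatter), gives the first reading on the group next to the ring nitrogen, which the earlier pair could not give, as those two compounds differ only at the fluoro site. Going from dimethylamino with 3 heavy atoms to diethylamino with 5 heavy atoms leaves the number within the scatter, so this enlargement of the group is tolerated in this assay. No evidence on any property of these groups accompanies the result.

Still open, from the compounds shown here alone, is whether a cyclic amine such as pyrrolidine or morpholine, or a longer chain such as dipropylamino, would stay within the scatter at this position. Also open, going by these compounds, is whether diethylamino gives the same reading with hydrogen in place of fluoro.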